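The source may hold more compounds than are shown below. What is called first, only, known or untested is meant among the compounds shown, and "the series" means these compounds.

Measured compounds:

Compound 1 `C=CC1=C(C(=O)NC(C)(C)C)C(c2ccc(OC)cc2)OC1`: in a functional assay on SW480 cells (Homo sapiens) for cytotoxicity, read by MTT assay, with a stated time of 24 h (a lower number here means a stronger inhibitor, a higher number a weaker inhibitor), compound 1 gives > 100000 nM, which is a limit of the assay and not a number.

Compound 2 `C=CC1=C(C(=O)NCCC)C(c2ccc(Cl)c(Cl)c2)OC1`: in this assay compound 2 gives > 100000 nM, again a limit of the assay.

Compound 1 stands at the limit of > 100000 nM in this assay, at which 2 of the 2 values shown sit. For the measured compounds named here, no number is known for it, only that its value lies at this limit. Compound 2 sits at the same limit, so the numbers shown do not separate the two compounds in any way, and no step between measured compounds can be read from them.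

Compound 3 `C=CC1=C(C(=O)Nc2ccc(C)cc2)C(c2ccc(OC)cc2)OC1` has not yet been measured in this assay. It differs from compound 1 in one place: 4-methylphenyl in place of tert-butyl on an amide-type nitrogen. Going by the values given here, with both measured values resting at the limit, there is no measured step to lean on, and the change is expected to give no step beyond the scatter in this assay. The estimated step is a number no higher from compound 1 to compound 3 (the limit leaves the size open). Compound 3 is therefore expected to come out near 100000 nM, within a range from 30000 nM to 300000 nM, with a strong chance that this assay again reports only a limit for it.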

Compound 3, half-maximal inhibitory concentration: > 100000 nM
Compound 3: only a limit was reported; the forecaster's own chance of this, stated with the estimate: 75%; the middle value lies on the limit itself.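

In this assay compound 3 gives > 100000 nM, which is a limit of the assay and not a number. For the compounds shown here, compound 1 also rests at a limit, so no step between compound 1 and compound 3 can be read. The compounds shown leave open whether any change to the shared core would give a measurable value in this assay.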